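The source may report more compounds than this note shows. Statements on the series, on what has been measured and on what is new or still open speak of the compounds shown alone.

In a functional assay on HCT-116 cells (Homo sapiens) for inhibition, with a stated time of 72 h (on this read-out higher numbers stand for weaker inhibition and lower numbers for stronger inhibition), compound 1 (`NC1CCC(Nc2nc(NCc3ccc(-c4ccco4)cc3)c3ncn(C4CCCC4)c3n2)CC1`) gives 129 nM, compound 2 (`NC1CCC(Nc2nc(NCc3ccc(-c4ccsc4)cc3)c3ncn(C4CCCC4)c3n2)CC1`) gives 315 nM, and compound 3 (`NC1CCC(Nc2nc(NCc3ccc(-c4ccccc4)nc3)c3ncn(C4CCCC4)c3n2)CC1`) gives 563 nM. Two steps place compound 3: there is a 1.8-fold higher number from compound 2 to compound 3 (0.25 log units; within the scatter), and a 4.4-fold higher number from compound 1 to compound 3 (0.64 log units; beyond the scatter). Compound 4 (`NC1CCC(Nc2nc(NCc3ccc(-c4ccccc4O)nc3)c3ncn(C4CCCC4)c3n2)CC1`) makes one small change, (hydroxy in place of hydrogen on an aromatic carbon), turning phenyl to 2-hydroxyphenyl. The nearest evidence is these two steps together with a 2.4-fold higher number from compound 1 to compound 2 (0.39 log units; beyond the scatter). All three swap one aromatic group for another, and all are modest or smaller, but none adds a hydroxy, so they offer only a rough guide to size. Going by these compounds, no shift beyond the scatter is therefore expected, and the direction remains open. The expected change is a 1.3-fold lower number from compound 3 to compound 4 (0.10 log units; within the scatter). For compound 4 the estimate is 450 nM, with an expected range of 140 nM to 1400 nM.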

Compound 4, half-maximal inhibitory concentration: 35 nM
Estimate against measurement, compound 4: 13-fold (1.11 log units) above; the whole stated range lies above it.
By their numbers in this assay, from the lowest: compound 4; then compound 1; then compounds 2 and 3 (each within the scatter of the next).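

In this assay adding one hydroxy to the phenyl gives a 16-fold lower number from compound 3 to compound 4 (1.21 log units; beyond the scatter) and this large step exceeds every step among the earlier swaps of one aromatic group for another. This carbon, ortho to a large group, is therefore highly sensitive to a small change, something those swaps could not reveal. Within the data shown here, nothing available here explains why a single added oxygen moves the number so far.

Going by these compounds, whether a methoxy or an amine on this carbon would give a similar step remains open. So does whether a hydroxy elsewhere on the phenyl would do the same.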